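The source may report more compounds than this note shows. Statements on the series, on what has been measured and on what is new or still open speak of the compounds shown alone.

Among the measured compounds shown here, in a functional assay on A549 cells (Homo sapiens) for cytotoxicity, read by WST assay, with a stated time of 48 h (on this read-out lower numbers stand for stronger inhibition and higher numbers for weaker inhibition), compound 1 `COc1ccc2[nH]cc(/C=C(\C#N)C(=O)c3c[nH]c4ccccc34)c2c1` gives 13700 nM, and compound 2 `COc1ccc2[nH]cc(/C=C(\C#N)C(=O)c3c[nH]c4cc(F)ccc34)c2c1` gives 26300 nM, so compound 2 stands level with the only other measured compound. Compound 3 `COc1ccc2c(C(=O)/C(C#N)=C/c3c[nH]c4ccc(OC)cc34)c[nH]c2c1` has methoxy in place of fluoro on an aromatic carbon. For the measured compounds named here, the only measured change at that carbon is fluoro in place of hydrogen, a 1.9-fold higher number from compound 1 to compound 2 (0.28 log units; within the scatter), and it is small, so no step beyond the scatter is expected in this assay. The expected step is a 1.5-fold lower number from compound 2 to compound 3 (0.16 log units; within the scatter). For compound 3 the estimated value is 18000 nM, with an expected range of 6000 nM to 50000 nM.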

Compound 3, half-maximal inhibitory concentration: 5500 nM
Compound 3: the middle estimate sits 3.3-fold (0.51 log units) above what was measured; the whole stated range lies above it.
By their numbers in this assay, from the lowest: compound 3; then compounds 1 and 2 (each within the scatter of the next).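

In this assay, placing methoxy on this aromatic carbon gives a 4.8-fold lower number from compound 2 to compound 3 (0.68 log units; beyond the scatter) when it replaces fluoro, and a 2.5-fold lower number from compound 1 to compound 3 (0.40 log units; beyond the scatter) when it replaces hydrogen. This carbon therefore does respond to the group it carries, which the step from hydrogen to fluoro, within the scatter, could not show. No measurement shown here gives a reason for this difference. Still open, as far as these compounds go, is whether an ethoxy group, a hydroxyl or an amine on this carbon would lower the number further, and whether methoxy would do the same elsewhere on the shared core.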